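Swapping a sulfonyl for a carbamoyl at the assay limit

The source may hold more compounds than are shown below. What is called first, only, known or untested is meant among the compounds shown, and "the series" means these compounds.

Compound 1 `O=C1CC[C@@H](C(=O)N2CCN(c3nccc(Oc4cc(Cl)cc(Cl)c4)n3)CC2)N1`: > 50000 nM, a limit
Compound 2 `O=S(=O)(c1ccc(F)cc1)N1CCN(c2nccc(Oc3cc(Cl)cc(Cl)c3)n2)CC1`: > 50000 nM, a limit

In a functional assay on MDA-MB-231 cells (Homo sapiens) for antiproliferative activity, read by MTT assay, with a stated time of 24 h (on this read-out lower numbers stand for stronger inhibition and higher numbers for weaker inhibition), compound 2 gives > 50000 nM, which is a limit of the assay and not a number. Compound 1 gives > 50000 nM, which is also a limit. Compound 2 therefore offers no exact potency as a starting point, and the whole record so far is this: the limit of > 50000 nM in this assay, at which 2 of the 2 values shown sit.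

Compound 3 `O=C(Nc1cccc(Cl)c1)N1CCN(c2nccc(Oc3cc(Cl)cc(Cl)c3)n2)CC1` keeps the shared core and changes one group: (3-chlorophenyl)carbamoyl in place of (4-fluorophenyl)sulfonyl on an amine nitrogen in a ring. For the measured compounds named here, one measured step touches the same place, a step that the two limits leave unreadable from compound 1 to compound 2, and it has no readable size or direction. No step beyond the usual scatter is therefore expected, and in this assay another limit is the likeliest report. The expected step is an at least 1.2-fold lower number from compound 2 to compound 3 (0.09 log units; that floor lies within the scatter). The estimate for compound 3 is 40000 nM, with an expected range from 10000 nM to 80000 nM.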

Compound 3, half-maximal inhibitory concentration: 7900 nM
Beside the measured number, compound 3's estimate is 5.1-fold (0.70 log units) above it; the measured number lies below the stated range.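

This position, on an amine nitrogen in a ring, can move the read-out: in this assay, (3-chlorophenyl)carbamoyl in place of (4-fluorophenyl)sulfonyl gives an at least 6.3-fold lower number from compound 2 to compound 3 (0.80 log units; beyond the scatter). The comparison with the other end of the series points the same way, with (3-chlorophenyl)amino in place of 5-oxopyrrolidin-2-yl on a carbonyl carbon giving an at least 6.3-fold lower number from compound 1 to compound 3 (0.80 log units; beyond the scatter), so a carbonyl at this place is not enough on its own for a readable number. Compound 1 and compound 2 stay at a limit, which makes both steps floors whose true size is unknown: the limit of > 50000 nM in this assay, at which 2 of the 3 values shown sit.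

The change from compound 2 to compound 3 swaps the linking group and the halogen-bearing ring together, so the compounds shown cannot say which of the two matters. A plain phenyl, or a methoxy in place of the chlorine on the carbamoyl group, would begin to separate these parts.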